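A further fluoro on compound 1

The source may report more compounds than this note shows. Statements on the series, on what has been measured and on what is new or still open speak of the compounds shown alone.

Compound 1 `Cn1nc(-c2ccccc2F)n(C)c1=S` gives 0.74 mg/kg
Compound 2 `Cn1nc(-c2ccccc2)n(C)c1=S` gives 0.15 mg/kg

Both values come from a functional assay on the whole organism with Mus musculus as the target; a higher number here means that more compound is needed for the effect, a lower number that less compound is needed. Of the two compounds measured in this assay, compound 1 has the higher number, so more of it is needed for the effect. The next compound to be measured is compound 3 `Cn1nc(-c2c(F)cccc2F)n(C)c1=S`, which differs from compound 1 by fluoro in place of hydrogen on an aromatic carbon.

Going by the values given here, only one measured step bears on this change: a 4.9-fold lower number from compound 1 to compound 2 (0.69 log units; beyond the scatter). That step removes a fluoro, and it lies beyond the usual scatter. Read in reverse, it suggests that adding fluoro to compound 3 may raise the number again. However, it concerns a different aromatic carbon, and there is only one such step, so it is a rough guide. A rise smaller than the measured step is therefore expected in this assay. The expected step is a 2.4-fold higher number from compound 1 to compound 3 (0.39 log units; beyond the scatter). For compound 3 the estimated value is 1.8 mg/kg, with an expected range of 0.5 mg/kg to 6 mg/kg.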

Compound 3, dose for half-maximal effect: 0.44 mg/kg
Beside the measured number, compound 3's estimate is 4.1-fold (0.61 log units) above it; the whole stated range lies above it.
By their numbers in this assay, from the lowest: compound 2; then compounds 3 and 1 (each within the scatter of the next).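

In this assay, fluoro in place of hydrogen on an aromatic carbon ortho to a group of 8 heavy atoms and meta to a fluoro group gives a 1.7-fold lower number from compound 1 to compound 3 (0.23 log units; within the scatter) and so leaves compounds 1 and 3 indistinguishable in this read-out. Going by these compounds alone, the only earlier step involving a fluoro, a 4.9-fold lower number from compound 1 to compound 2 (0.69 log units; beyond the scatter), lies beyond the scatter, so within this small set a step at one aromatic carbon does not predict the size of a step at another, and each position has to be read on its own. No measurement to hand accounts for the difference between these two steps.

On these data alone, whether this carbon accepts larger or different groups in the same way remains open, for example chloro, methyl, methoxy, an amine or a carboxylic acid, as does the outcome of a fluoro on the remaining carbons of the ring. This change also rests on a single pair that already carries a fluoro, so its size in the absence of that first fluoro cannot be judged from the compounds shown.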